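Carboxamide for carboxylic acid in a solubility series

The source may report more compounds than this note shows. Statements on the series, on what has been measured and on what is new or still open speak of the compounds shown alone.

Of the compounds shown here, two sharing one core have been measured in a physicochemical assay for solubility, using the shake flask method, in phosphate buffer, measured as kinetic solubility, with a stated time of 20 h, at pH 6.5; on this read-out higher numbers stand for higher solubility and lower numbers for lower solubility. Compound 1 `COc1cccnc1Nc1cc2[nH]c(-c3cccc(C(F)(F)F)c3)nc2cn1` carries a 3-methoxypyridin-2-yl group on the ring nitrogen. In this assay compound 1 returns only a limit of the assay, < 5000 nM. Compound 2 `O=C(O)c1ccnc(Nc2cc3[nH]c(-c4cccc(C(F)(F)F)c4)nc3cn2)c1` carries a 4-carboxypyridin-2-yl group at the same place. In this assay compound 2 likewise returns only a limit, < 5000 nM. The step that the two limits leave unreadable from compound 1 to compound 2 therefore cannot be read in size; both values sit at the same floor, as the limit of < 5000 nM in this assay, at which 2 of the 2 values shown sit, records, so compound 2 stands no higher than that limit and nothing more is known of its position.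

Compound 3 `NC(=O)c1ccc(Nc2cc3[nH]c(-c4cccc(C(F)(F)F)c4)nc3cn2)nc1` is the next member. It differs from compound 2 by 5-carbamoylpyridin-2-yl in place of 4-carboxypyridin-2-yl on a nitrogen on an aromatic ring. Within the data shown here, the only measured step on this nitrogen is the unreadable one from compound 1 to compound 2, so it gives no size to lean on. With both measured neighbours at the floor, the expected step that the limit leaves unreadable from compound 2 to compound 3 is small and most likely not readable. The estimated solubility of compound 3 is 2000 nM, within 300 nM to 8000 nM.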

Compound 3, solubility: < 5000 nM
Compound 3: only a limit was reported; the forecaster's own chance of this, stated with the estimate: 70%; the middle value does not contradict the limit.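

Among these compounds, compound 3 also returns only a limit in this assay and so no step among compound 1, compound 2 and compound 3 can be read; all three sit at the same floor: the limit of < 5000 nM in this assay, at which 3 of the 3 values shown sit. The compounds shown leave open where each true value lies under that limit, and whether the 3-methoxypyridin-2-yl, 4-carboxypyridin-2-yl and 5-carbamoylpyridin-2-yl groups differ at all on this read-out.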